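Piperazinyl acetamide oxindoles: ghrelin receptor antagonism, one ring swap

A few compounds are considered here, and "the series" means these few. Any claim that something is new, unique, unknown or untested is made for them only; others in the source may bear on it.

Measured compounds
- compound 1 `CCN1CCN(CC(=O)NC2(c3ccc(Cl)cc3)C(=O)Nc3cc(Cl)c(Cl)cc32)CC1`: 110 nM
- compound 2 `Cc1cc2c(cc1Cl)NC(=O)C2(NC(=O)CN1CCN(C)CC1)c1ccc(Cl)cc1Cl`: > 10000 nM
- compound 3 `CN1CCN(CC(=O)NC2(c3ccc(C(C)(C)C)cc3)C(=O)Nc3cc(Cl)c(Cl)cc32)CC1`: 1470 nM

In an in vitro functional assay on CHO-CREluc cells for antagonist activity at growth hormone secretagogue receptor type 1 (Homo sapiens), read by a luciferase reporter, with a stated time of 4 h (on this read-out lower numbers stand for stronger inhibition and higher numbers for weaker inhibition), compound 1 gives 110 nM and compound 3 gives 1470 nM. Compound 2 gives only a limit, > 10000 nM, not a number. Compound 2 thus sits at the limit of > 10000 nM in this assay, at which 1 of the 3 values shown sits, so where it stands among the measured compounds can only be said as being beyond the weak end of the numbers shown.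

Compound 4 `Cc1cc2c(cc1Cl)NC(=O)C2(NC(=O)CN1CCN(C)CC1)c1cccc(Cl)c1` differs from compound 2 in one place: 3-chlorophenyl in place of 2,4-dichlorophenyl on a saturated ring carbon. Going by the values given here, no pair of measured compounds differs in a single place, so no measured step guides the size or direction of this change; the comparison between compound 2 and compound 4 has to be read from the two values alone once compound 4 is known in this assay.

Since compound 2 only reached a limit, any number for compound 4 would itself be a change of unknown size from compound 2. Compound 4 is estimated at 3000 nM, with a range from 600 nM to 10000 nM. This estimate would mean a step of an at least 3.3-fold lower number from compound 2 to compound 4 (0.52 log units; beyond the scatter), if compound 4 is in fact measured as a number.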

Compound 4, half-maximal inhibitory concentration: 1180 nM
Compound 4: the middle estimate sits 2.5-fold (0.41 log units) above what was measured; measured number inside the range.
By their numbers in this assay, from the lowest: compound 1; then compounds 4 and 3 (each within the scatter of the next). At a limit, above all of these: compound 2.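

In this assay, the aryl group on a saturated ring carbon of the five-membered ring proves to be a position that matters with the rest of the molecule held fixed: 3-chlorophenyl in place of 2,4-dichlorophenyl gives an at least 8.4-fold lower number from compound 2 to compound 4 (0.92 log units; beyond the scatter). Going by these compounds alone, this is the first single-place step, and it shows that this change alone is enough to bring the read-out from a limit to a measured number. The full size of the step stays open, since compound 2 stands only at a limit and not at a number: the limit of > 10000 nM in this assay, at which 1 of the 4 values shown sits.

The step alters the chlorine pattern as a whole, so it does not tell which chlorine carries the difference. On these data alone, how a methoxy group or a nitrile on this phenyl ring, or a pyridine ring in its place, would read at this position remains open.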